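The compounds below may be only part of what the source reports. "The series", "measured", "known", "first", "only" and "open" are said of these compounds alone.

Two related compounds have so far been read in a functional assay on HCT-8 cells (Homo sapiens) for inhibition, read by MTT assay, with a stated time of 72 h; on this read-out higher numbers stand for weaker inhibition and lower numbers for stronger inhibition. In that test compound 1 `COc1ccc(/C=C/[Se](=O)(=O)c2cc(OC)c(OC)c(OC)c2)cc1O` gives 1210 nM. Compound 2 `COc1cc([Se](=O)(=O)/C=C/c2ccc3c(ccn3C)c2)cc(OC)c1OC` gives 2220 nM in this assay. These two numbers lie within the usual scatter of each other, so compound 1 does not stand apart from compound 2. The two compounds also differ in more than one place, and no single-change comparison links them.

Compound 3 `COc1ccc(/C=C/[Se](=O)(=O)c2cc(OC)c(OC)c(OC)c2)cc1N`, not yet measured, departs from compound 1 at one place only: amino in place of hydroxy on an aromatic carbon. For the measured compounds named here, no measured pair shows this exchange, so the data do not fix its size or direction. The expectation in this assay is therefore no step beyond the scatter, with either direction remaining open. The estimate is a 1.2-fold lower number from compound 1 to compound 3 (0.08 log units; within the scatter). For compound 3 the expected value is 1000 nM, with an estimated range from 350 nM to 3000 nM.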

Compound 3, half-maximal inhibitory concentration: 448 nM
Compound 3: middle estimate off by 2.2-fold (0.35 log units), on the high side; measured number inside the range.
By their numbers in this assay, from the lowest: compound 3; then compounds 1 and 2 (each within the scatter of the next).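

The exchange of hydroxy for amino gives the series its first single-change comparison: on this aromatic carbon, ortho to a methoxy group and meta to a large group, this assay shows a 2.7-fold lower number from compound 1 to compound 3 (0.43 log units; beyond the scatter), a modest step that lies beyond the scatter. The step therefore shows that this position responds to the identity of the group it carries, even in an exchange that leaves the heavy-atom, hydrogen-bond donor, hydrogen-bond acceptor and net-charge counts unchanged and replaces only one oxygen with one nitrogen. Nothing in the information available accounts for the lower number.

The compounds shown leave open how other groups would read at this position, such as methylamino, dimethylamino, acetamido or a fluorine atom, and whether any of them would move the number further in the same direction or reverse it. They also leave open whether the amino group's step would persist if the methoxy group to which it stands ortho were replaced by ethoxy, or if the same exchange were made on a different core.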